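This account rests on a few compounds, and the source may have more. Where it says the series, first, only, none or still open, it means among the compounds named here.

Measured in a functional assay on HT29-AK cells (Homo sapiens) for cytotoxicity, read by MTT assay, with a stated time of 48 h; a higher number here means a weaker inhibitor, a lower number a stronger inhibitor:
- compound 1 `Fc1cccc(-c2nc(Nc3ccccc3)c3cc(F)ccc3n2)c1`: 48300 nM
- compound 2 `Nc1cccc(Nc2nc(-c3cccc(F)c3)nc3ccc(F)cc23)c1`: > 50000 nM (a limit)
- compound 3 `Nc1ccccc1Nc1nc(-c2cccc(F)c2)nc2ccc(F)cc12`: > 50000 nM (a limit)

Compound 3 has no number of its own: its entry of > 50000 nM is a limit. That entry is the limit of > 50000 nM in this assay, at which 2 of the 3 values shown sit, so the starting point for this step is only a bound.

The unmeasured compound 4 `Cc1ccccc1Nc1nc(-c2cccc(F)c2)nc2ccc(F)cc12` carries methyl in place of amino on an aromatic carbon, ortho to a large group. Within the data shown here, no compound with this methyl has been measured, so the nearest evidence comes from the amino group itself. Two steps add amino to compound 1, and they read an at least 1.0-fold higher number from compound 1 to compound 2 (0.01 log units; that floor lies within the scatter) and an at least 1.0-fold higher number from compound 1 to compound 3 (0.01 log units; that floor lies within the scatter). Neither shows a change beyond the scatter. The move of the amino group is no help either, as it reads a step that the two limits leave unreadable from compound 2 to compound 3.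

Compound 1, which has no amino group, gives 48300 nM. Compound 4 also lacks the amino group, so a value in the same region is expected, and no step beyond the scatter is expected in this assay, in either direction. The expected step is an at least 1.0-fold lower number from compound 3 to compound 4 (0.02 log units; that floor lies within the scatter). The estimated value for compound 4 is 47000 nM, with an expected range from 25000 nM to 70000 nM.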

Compound 4, half-maximal inhibitory concentration: > 50000 nM
Compound 4 gave a limit, no number (the forecaster's own chance of this, stated with the estimate: 55%); at least 1.0-fold (0.02 log units) between middle value and limit.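

In this assay, compound 4 gives a limit and no number, so methyl on this aromatic carbon, ortho to a large group, gives no readable value, just as amino does in compound 3; the steps from compound 3 and from compound 2 to compound 4 cannot be read. Among these compounds, the one readable step is an at least 1.0-fold higher number from compound 1 to compound 4 (0.01 log units; that floor lies within the scatter), and as a floor it shows no change beyond the scatter for methyl in place of hydrogen, though it does not exclude a larger change. The position now holds two different groups that both end at the same limit, and the series gathers there: the limit of > 50000 nM in this assay, at which 3 of the 4 values shown sit.

Going by these compounds, whether compounds 2, 3 and 4 truly differ from one another stays open, since their limits give no order among them. On these data alone, it is also open whether a hydroxyl group, a chlorine atom or a longer chain such as ethyl on this carbon would give a value that can be read as a number.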